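The compounds below may be only part of what the source reports. "The series", "measured", "known", "first", "only" and "open" are said of these compounds alone.

Measured compounds:
compound 1, `O=C(Nc1nc2ccccc2s1)c1cn(-c2ccccc2)nc1-c1ccc(Cl)cc1`, 10300 nM
compound 2, `COc1ccc(-c2nn(-c3ccccc3)cc2C(=O)Nc2nc3ccccc3s2)cc1`, 13700 nM
compound 3, `COc1ccc(-c2nn(-c3ccccc3)cc2C(=O)Nc2nc3ccc(Cl)cc3s2)cc1`, 4710 nM

Three compounds sharing an amide-linked benzothiazole motif were measured in a functional assay on A549 cells (Homo sapiens) for cytotoxicity, read by MTT assay, with a stated time of 72 h; on this read-out higher numbers stand for weaker inhibition and lower numbers for stronger inhibition. Compound 1 is `O=C(Nc1nc2ccccc2s1)c1cn(-c2ccccc2)nc1-c1ccc(Cl)cc1` and in this assay gives 10300 nM. Compound 2, `COc1ccc(-c2nn(-c3ccccc3)cc2C(=O)Nc2nc3ccccc3s2)cc1`, gives 13700 nM. Compound 3, `COc1ccc(-c2nn(-c3ccccc3)cc2C(=O)Nc2nc3ccc(Cl)cc3s2)cc1`, gives 4710 nM and is the strongest inhibitor of the three.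

Going from compound 1 to compound 2 the change is methoxy in place of chloro on an aromatic carbon, and it made a 1.3-fold higher number from compound 1 to compound 2 (0.12 log units; within the scatter). Going from compound 2 to compound 3 the change is chloro in place of hydrogen on an aromatic carbon, which made a 2.9-fold lower number from compound 2 to compound 3 (0.46 log units; beyond the scatter). The difference between the cores of compound 1 and compound 3 is not broken down here.

Compound 4, `COc1ccc(-c2nn(-c3ccccc3)cc2C(=O)Nc2nc3ccc(OC)cc3s2)cc1`, has not yet been measured. It differs from compound 3 by methoxy in place of chloro on an aromatic carbon. Going by the values given here, this is the same kind of change as the one from compound 1 to compound 2, though the surroundings differ: there the place was para to a large group, while here it is part of a fused or bridged system of two rings, meta and para to a fused ring.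

Because the earlier instance of this change gave a 1.3-fold higher number from compound 1 to compound 2 (0.12 log units; within the scatter), compound 4 is expected to stay close to compound 3, with an estimated step of a 1.3-fold higher number from compound 3 to compound 4 (0.11 log units; within the scatter). For compound 4 the estimate in this assay is 6000 nM, expected to fall between 3000 nM and 14000 nM.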

Compound 4, half-maximal inhibitory concentration: 18900 nM
Compound 4: the middle estimate sits 3.2-fold (0.50 log units) below what was measured; measured number outside the range, above it.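

In this assay, exchanging chloro for methoxy on the aromatic carbon of the 6-chloro-1,3-benzothiazol-2-yl group gives a 4.0-fold higher number from compound 3 to compound 4 (0.60 log units; beyond the scatter), and this change does not carry over in size from the earlier core: the same change on two cores in this assay, a 1.3-fold higher number (0.12 log units; within the scatter) from compound 1 to compound 2 and a 4.0-fold higher number (0.60 log units; beyond the scatter) from compound 3 to compound 4, 3.0-fold (0.48 log units) apart, beyond the scatter of two such steps. Methoxy in place of hydrogen at this same place gives a 1.4-fold higher number from compound 2 to compound 4 (0.14 log units; within the scatter), so among compound 2, compound 3 and compound 4 the chloro group of compound 3 alone sets a compound apart from the other two. This does not show why the two chloro-to-methoxy steps differ, since they rest on one pair each and differ both in the ring that carries the change and in the surroundings of that ring, so the place and the rest of the core cannot be separated.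

The compounds shown leave open whether the chloro-to-methoxy step on the other ring would keep its size in a compound that also carries chloro at the 6-position of the fused system. They also leave open how other groups on that same aromatic carbon, such as fluoro, bromo, an amine or a carboxylic acid, would compare with chloro and methoxy.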